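A few compounds are considered here, and "the series" means these few. Any claim that something is new, unique, unknown or untested is made for them only; others in the source may bear on it.

Compound 1 `CCOC(=O)C1=Cc2ccccc2OC1(OCc1cn(-c2cccc(OC)c2)nn1)C(F)(F)F` is the starting point. In a functional assay on A549 cells (Homo sapiens) for inhibition, read by MTT assay, with a stated time of 24 h (a higher number here means a weaker inhibitor, a lower number a stronger inhibitor), compound 1 gives only a limit, > 150000 nM. Compound 2 `O=C(O)C1=Cc2ccccc2OC1(OCc1cc(-c2ccc(F)cc2)no1)C(F)(F)F` shares the same core. In this assay compound 2 likewise returns only a limit, > 150000 nM. Within the data shown here, every value so far sits at the same boundary (the limit of > 150000 nM in this assay, at which 2 of the 2 values shown sit), so compound 1 has no measured neighbour to rank against. Compound 3 `CCOC(=O)C1=Cc2ccccc2OC1(OCc1cn(-c2ccc(F)c(Cl)c2)nn1)C(F)(F)F` differs from compound 1 by 3-chloro-4-fluorophenyl in place of 3-methoxyphenyl on an aromatic nitrogen. Among the measured compounds shown here, with no measured step available, the expected step is a number no higher from compound 1 to compound 3 (the limit leaves the size open), nothing beyond the usual scatter. Compound 3 is estimated at 150000 nM, with a range from 50000 nM to 500000 nM, and is expected most likely to appear again only as a limit.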

Compound 3, half-maximal inhibitory concentration: 26300 nM
Beside the measured number, compound 3's estimate is 5.7-fold (0.76 log units) above it; measured number below the stated range.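

Exchanging 3-methoxyphenyl for 3-chloro-4-fluorophenyl on the aromatic nitrogen gives an at least 5.7-fold lower number from compound 1 to compound 3 (0.75 log units; beyond the scatter) in this assay, so the group at this position can move the read-out. Compound 3 is the only compound shown with a measured number rather than a limit, and the others remain at the boundary: the limit of > 150000 nM in this assay, at which 2 of the 3 values shown sit. Going by these compounds, the full size of the step stays unknown, since the value for compound 1 is only a limit.

The compounds shown leave open whether the chlorine or the fluorine alone would carry this step. They also leave open how an amine or a nitrile on this phenyl ring would read.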